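The compounds below may be only part of what the source reports. "The series", "measured", "known", "first", "only" and "open" are said of these compounds alone.

Measured so far in an ADME assay on cells (Rhabdomyosarcoma cell, Homo sapiens) for cytotoxicity, read by MTT assay, with a stated time of 72 h; a lower number here means that less compound is tolerated, a higher number that more compound is tolerated:
- compound 1 `Fc1ccccc1/C=N/c1sc2c(c1-c1nc3ccccc3s1)CCC2`: 270 ug/mL
- compound 2 `Clc1ccccc1/C=N/c1sc2c(c1-c1nc3ccccc3s1)CCC2`: 123 ug/mL
- compound 3 `Fc1ccc(/C=N/c2sc3c(c2-c2nc4ccccc4s2)CCCC3)cc1`: 230 ug/mL

Compound 3 sits within the scatter of compound 1 and of compound 2 in this assay; the difference between the core of compound 3 and the core of compound 1 is not broken down here. Among the compounds with values here, the one counted change in the set is chloro in place of fluoro on an aromatic carbon, which gives a 2.2-fold lower number from compound 1 to compound 2 (0.34 log units; beyond the scatter).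

Compound 4 `Clc1ccc(/C=N/c2sc3c(c2-c2nc4ccccc4s2)CCCC3)cc1` is not yet measured. It differs from compound 3 by chloro in place of fluoro on an aromatic carbon, the same kind of change as from compound 1 to compound 2, but the place differs: ortho to a large group there, para to a large group here. Taking the step from compound 1 to compound 2 as the only guide, a step of similar size, a 2.1-fold lower number from compound 3 to compound 4 (0.32 log units; beyond the scatter), is expected for compound 4, with wide uncertainty because of a 2.2-fold lower number from compound 1 to compound 2 (0.34 log units; beyond the scatter) being a single instance. Compound 4 is estimated at 110 ug/mL in this assay, expected between 55 ug/mL and 230 ug/mL.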

Compound 4, half-maximal cytotoxic concentration: 367 ug/mL
Beside the measured number, compound 4's estimate is 3.3-fold (0.52 log units) below it, outside the stated range (above it).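

In this assay, chloro in place of fluoro on an aromatic carbon gives a 1.6-fold higher number from compound 3 to compound 4 (0.20 log units; within the scatter), and this step does not match the one on the other core: the same change on two cores in this assay, a 2.2-fold lower number (0.34 log units; beyond the scatter) from compound 1 to compound 2 and a 1.6-fold higher number (0.20 log units; within the scatter) from compound 3 to compound 4, 3.5-fold (0.54 log units) apart, beyond the scatter of two such steps. The change therefore cannot be carried from one core to the other in this series as a fixed step. The two pairs differ in both the core and the place of the halogen on the ring, so these data do not show which of the two accounts for the gap.

On these data alone, it remains open whether fluoro and chloro at one shared place on both cores would give matching steps. Also open, as far as these compounds go, is how a methoxy group, a nitrile or an amine on that ring would read on either core.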